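Adding a methoxy to compound 1

This account rests on a few compounds, and the source may have more. Where it says the series, first, only, none or still open, it means among the compounds named here.

Compound 1 `COc1ccccc1/C=C1\CCC/C(=C\c2ccc(OC)c(OC)c2)C1=O` gives 18100 nM
Compound 2 `COc1ccc(/C=C2\CCC/C(=C\c3cc(Cl)cc(Cl)c3)C2=O)cc1OC` gives 8300 nM

Going by the values given here, in an ADME assay on NHDF cells (Homo sapiens) for cytotoxicity, read by MTT assay, with a stated time of 72 h (a higher number here means a weaker inhibitor, a lower number a stronger inhibitor), compound 1 holds the higher of the two numbers, so it is the weaker inhibitor of these cells, and compound 2 is its only neighbour. Compound 3 `COc1ccc(/C=C2\CCC/C(=C\c3ccc(OC)c(OC)c3)C2=O)c(OC)c1` keeps all of compound 1 and adds one group: methoxy in place of hydrogen on an aromatic carbon. In words, a methoxy takes the place of a hydrogen on an aromatic carbon, meta to a methoxy group and para to a large group.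

Among the compounds with values here, only one measured step bears on this change, a 2.2-fold lower number from compound 1 to compound 2 (0.34 log units; beyond the scatter). It was modest, and it swapped the whole 2-methoxyphenyl for a 3,5-dichlorophenyl, a larger edit than the one here. A single step cannot fix a direction for a different group. A change no larger than that modest step is therefore expected in this assay, with a slight drop at most and quite possibly nothing beyond the scatter. The estimated change is a 1.2-fold lower number from compound 1 to compound 3 (0.08 log units; within the scatter), which would leave the two compounds hard to tell apart. For compound 3 the expected value is 15000 nM, with an estimated range from 7500 nM to 30000 nM.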

Compound 3, half-maximal inhibitory concentration: > 50000 nM
Compound 3 gave a limit, no number; the forecaster's own chance of this, stated with the estimate: 5%; middle value at least 3.3-fold (0.52 log units) away from the limit.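

In this assay, compound 3 gives > 50000 nM, which is a limit of the assay and not a number. Even so, the direction can be read: a methoxy in place of a hydrogen on an aromatic carbon, meta to a methoxy group and para to a large group, gives an at least 2.7-fold higher number from compound 1 to compound 3 (0.44 log units; beyond the scatter), so adding just 2 heavy atoms to the 2-methoxyphenyl of compound 1 is enough to weaken inhibition of these cells beyond the scatter, whereas replacing that whole group with 3,5-dichlorophenyl went the other way, with a 2.2-fold lower number from compound 1 to compound 2 (0.34 log units; beyond the scatter). This aromatic ring can therefore move the number in either direction, and compound 3 is alone among the three compounds shown in reaching the top of the readable range: the limit of > 50000 nM in this assay, at which 1 of the 3 values shown sits.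

On these data alone, how far compound 3 really lies from compound 1 stays open, since only a lower bound on the step is available. As far as these compounds go, it is also open whether a hydroxyl, a fluorine or an amine in the same place would raise the number as the methoxy does, or whether this is particular to the methoxy.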